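Fluoro for methoxy at the limit of the assay

This account rests on a few compounds, and the source may have more. Where it says the series, first, only, none or still open, it means among the compounds named here.

Compound 1 `COc1ccccc1NC(=O)SC[C@H](NC(C)=O)C(=O)O`: > 200000 nM
Compound 2 `CC(=O)N[C@@H](CSC(=O)Nc1ccccc1F)C(=O)O`: > 200000 nM
Compound 3 `COc1ccc(NC(=O)SC[C@H](NC(C)=O)C(=O)O)cc1`: > 200000 nM

In a functional assay on GC3/C1 cells (Homo sapiens) for cytotoxicity, read by MTT assay, with a stated time of 6 days (a higher number here means a weaker inhibitor, a lower number a stronger inhibitor), compound 3 gives > 200000 nM, which is a limit of the assay and not a number. The other two measured compounds also give only limits, so compound 3 has no readable rank among them. The whole picture so far is the limit of > 200000 nM in this assay, at which 3 of the 3 values shown sit.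

Compound 4 `CC(=O)N[C@@H](CSC(=O)Nc1ccc(F)cc1)C(=O)O` differs from compound 3 in one place: fluoro in place of methoxy on an aromatic carbon. The fluoro stands in place of the methoxy on an aromatic carbon, para to a large group.

Among the compounds with values here, one measured step bears on this change, the same exchange of groups: a step that the two limits leave unreadable from compound 1 to compound 2. It offers no size to carry over, and it shows no sign of a gain on leaving the methoxy.

The expected step in this assay, a number no higher from compound 3 to compound 4 (the limit leaves the size open), is none beyond the scatter, with neither direction favoured. For compound 4 the estimate is 200000 nM, with an expected range from 100000 nM to 400000 nM.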

Compound 4, half-maximal inhibitory concentration: 114000 nM
Beside the measured number, compound 4's estimate is 1.8-fold (0.24 log units) above it; low and high end bracket the measured number.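

In this assay compound 4 gives 114000 nM, the only number among the compounds shown, so the fluoro on this aromatic carbon, para to a large group, gives the first readable value in the series. As far as these compounds go, the exchange of methoxy for fluoro here gives an at least 1.7-fold lower number from compound 3 to compound 4 (0.24 log units; that floor lies within the scatter), so it has a direction that the same exchange in the earlier pair could not show, though its true size stays open and its floor does not clear the scatter. The other compounds remain at a limit and not a number: the limit of > 200000 nM in this assay, at which 3 of the 4 values shown sit.

From the compounds shown here alone, how an ester in place of the carboxylic acid, or a free amine in place of the acetamide, would read in this assay stays open. So does whether a chloro or a trifluoromethyl at this same place would behave as the fluoro does.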